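Chloro for hydrogen on the aryl ring of compound 2

The source may report more compounds than this note shows. Statements on the series, on what has been measured and on what is new or still open speak of the compounds shown alone.

Compound 1 `O=C(NC(=S)Nc1ccc(F)cc1)c1cn(-c2ccccc2)nc1-c1ccc(F)cc1` gives 3240 nM in a functional assay on NCI-H460 cells (Homo sapiens) for inhibition, read by CCK-8 assay, with a stated time of 48 h; on this read-out lower numbers stand for stronger inhibition and higher numbers for weaker inhibition.
Compound 2 `O=C(NC(=S)Nc1ccc(F)cc1)c1cn(-c2ccccc2)nc1-c1ccccc1` gives 4210 nM in this assay.

Among the measured compounds shown here, compound 2 holds the highest of the two numbers measured so far; its nearest neighbour is compound 1, and the step of a 1.3-fold higher number from compound 1 to compound 2 (0.11 log units; within the scatter), hydrogen in place of fluoro on an aromatic carbon, stays within the scatter, so the two cannot be ordered. Compound 3 `O=C(NC(=S)Nc1ccc(F)cc1)c1cn(-c2ccccc2)nc1-c1ccc(Cl)cc1` is the next member and is not yet measured. It differs from compound 2 by chloro in place of hydrogen on an aromatic carbon. For the measured compounds named here, the one measured step that bears on this change is a 1.3-fold higher number from compound 1 to compound 2 (0.11 log units; within the scatter), which stayed within the scatter; with chloro now entering on the same aromatic carbon that carried fluoro in compound 1, the expected step of a 1.4-fold lower number from compound 2 to compound 3 (0.15 log units; within the scatter) in this assay is small, toward a somewhat lower number at most. Compound 3 is therefore expected to give about 3000 nM, within 1500 nM to 6500 nM.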

Compound 3, half-maximal inhibitory concentration: 3640 nM
Estimate against measurement, compound 3: 1.2-fold (0.08 log units) below; the measured number falls inside the stated range.
By their numbers in this assay, from the lowest: compounds 1, 3 and 2 (each within the scatter of the next).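

With chloro in place of hydrogen on the aromatic carbon para to a large group, this assay shows a 1.2-fold lower number from compound 2 to compound 3 (0.06 log units; within the scatter) and, with chloro in place of fluoro at that same carbon, a 1.1-fold higher number from compound 1 to compound 3 (0.05 log units; within the scatter) and neither step leaves the scatter. Hydrogen, fluoro and chloro at this position therefore cannot be ordered among compounds 1, 2 and 3, and the second halogen adds no separation that compound 1 and compound 2 had failed to show. No measurement on hand accounts for these numbers.

Going by these compounds, whether an amine, a carboxylic acid or a longer chain at this position would move the number beyond the scatter remains open. Also open, on these data alone, is whether changes elsewhere on the shared core would give a readable step in this cell line.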